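Swapping a urea arm for cyclohexylmethyl on compound 3

A few compounds are considered here, and "the series" means these few. Any claim that something is new, unique, unknown or untested is made for them only; others in the source may bear on it.

Compound 1 `O=C(Nc1ccc(Nc2nccc(NC3CCCC3)n2)cc1)NC1CCCCC1` gives 19200 nM
Compound 2 `O=C(Nc1ccc(Nc2nccc(NC3CCCC3)n2)cc1)Nc1cccc(C(F)(F)F)c1` gives 5180 nM
Compound 3 `O=C(Nc1ccc(Cl)cc1)Nc1ccc(Nc2nccc(NC3CCCC3)n2)cc1` gives 22000 nM

These numbers come from a functional assay on MCF7 cells (Homo sapiens) for antiproliferative activity, read by MTT assay, with a stated time of 72 h (a lower number here means a stronger inhibitor, a higher number a weaker inhibitor), and put compound 3 at the high-number end of the set. It shares that end with compound 1 (a 1.1-fold higher number from compound 1 to compound 3 (0.06 log units; within the scatter)). Compound 2 stands clearly apart (a 4.2-fold higher number from compound 2 to compound 3 (0.63 log units; beyond the scatter)).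

Compound 4 `O=C(CC1CCCCC1)Nc1ccc(Nc2nccc(NC3CCCC3)n2)cc1` carries cyclohexylmethyl in place of (4-chlorophenyl)amino on a carbonyl carbon. For the measured compounds named here, no measured step makes this exact change. The closest one exchanges cyclohexyl and 4-chlorophenyl on an amide-type nitrogen, and it stays within the scatter (a 1.1-fold higher number from compound 1 to compound 3 (0.06 log units; within the scatter)). Going by the values given here, the only steps beyond the scatter are modest and involve 3-(trifluoromethyl)phenyl, a group absent from this change (a 3.7-fold lower number from compound 1 to compound 2 (0.57 log units; beyond the scatter)). The data hold no case in which the amide-type nitrogen on that carbonyl carbon is lost, so the range is kept wide. In this assay the expected outcome is no step beyond the scatter (estimated as a 1.3-fold lower number from compound 3 to compound 4 (0.11 log units; within the scatter)). Compound 4 is therefore estimated at 17000 nM (expected range 7000 nM to 40000 nM).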

Compound 4, half-maximal inhibitory concentration: 17600 nM
The estimate for compound 4 lay 1.0-fold (0.02 log units) below the measured number; low and high end bracket the measured number.
By their numbers in this assay, from the lowest: compound 2; then compounds 4, 1 and 3 (each within the scatter of the next).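

The new compound shows that in this assay this position tolerates losing the amide-type nitrogen on the carbonyl carbon, along with the hydrogen-bond donor counted in the group that leaves: cyclohexylmethyl in place of (4-chlorophenyl)amino stays within the scatter (a 1.3-fold lower number from compound 3 to compound 4 (0.10 log units; within the scatter)), and so does cyclohexylmethyl in place of cyclohexylamino (a 1.1-fold lower number from compound 1 to compound 4 (0.04 log units; within the scatter)). The urea and the amide therefore cannot be told apart when the arm is one of these groups, and the exchange of an aromatic ring for a non-aromatic one on the amide side makes no readable difference either. Compound 2 remains the only one set apart, with a modest step beyond the scatter (a 3.4-fold higher number from compound 2 to compound 4 (0.53 log units; beyond the scatter)), and no measurement given here explains that gap or the flat behaviour of the other three compounds.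

The compounds shown leave open whether the urea nitrogen matters once 3-(trifluoromethyl)phenyl is the arm, as a (3-(trifluoromethyl)phenyl)methyl group on the same carbonyl carbon would test. They also do not tell how a longer chain, or a cyclohexyl ring carrying an amine or a carboxylic acid, would read at this position.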